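A pyrazine in place of a pyridine on compound 1

A few compounds are considered here, and "the series" means these few. Any claim that something is new, unique, unknown or untested is made for them only; others in the source may bear on it.

Measured compounds:
compound 1, `CCN(C(=O)CN(c1cc(N(C)C)ccc1Cl)S(=O)(=O)c1ccc(OC)c(OC)c1)c1cccc(C)n1`: 17 nM
compound 2, `CCN(CC)C(=O)CN(c1ccc(C)cc1)S(=O)(=O)c1cccc(C)c1`: > 10000 nM
compound 3, `CCN(CC)C(=O)CN(c1ccc(C)cc1)S(=O)(=O)c1cccc(F)c1`: > 10000 nM

Among the measured compounds shown here, in a functional assay on CHO cells for inhibition of Orexin/Hypocretin receptor type 1 (Homo sapiens), read by FLIPR and calcium flux (on this read-out lower numbers stand for stronger inhibition and higher numbers for weaker inhibition), compound 1 gives 17 nM, the only number among the three values shown. For compound 2 the result is a limit of the assay, > 10000 nM. For compound 3 the result is likewise a limit, > 10000 nM. Both of those values sit at the limit of > 10000 nM in this assay, at which 2 of the 3 values shown sit, so the step that the two limits leave unreadable from compound 2 to compound 3 cannot be sized. For the measured compounds named here, compound 2 and compound 3 differ from compound 1 in several places at once, and no measured pair isolates a change on the amide-type nitrogen.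

The unmeasured compound 4 `CCN(C(=O)CN(c1cc(N(C)C)ccc1Cl)S(=O)(=O)c1ccc(OC)c(OC)c1)c1cnc(C)cn1` differs from compound 1 by 5-methylpyrazin-2-yl in place of 6-methylpyridin-2-yl on an amide-type nitrogen. Going by the values given here, no measured step bears on this change, and the two values at the limit give no scale for it. What remains is the value of compound 1 itself, 17 nM, as the anchor. With nothing to argue for a shift in either direction beyond the usual scatter, the step from compound 1 to compound 4 is expected to be small, a 1.5-fold higher number from compound 1 to compound 4 (0.17 log units; within the scatter). Compound 4 is therefore estimated at 25 nM in this assay, within a range from 6 nM to 110 nM.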

Compound 4, half-maximal inhibitory concentration: 5 nM
Compound 4: the middle estimate sits 5.0-fold (0.70 log units) above what was measured; measured number below the stated range.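

In this assay, placing 5-methylpyrazin-2-yl where 6-methylpyridin-2-yl stood on the amide-type nitrogen gives a 3.4-fold lower number from compound 1 to compound 4 (0.53 log units; beyond the scatter). Among the compounds shown here, this is the first step that can be read and sized, as the one earlier step cannot be read, and it shows that this position on the amide-type nitrogen responds to a change of the aromatic ring, with the ring bearing 2 hetero atoms giving the lower number. No measurement shown accounts for this step, which changes both the hetero atoms of the ring and the place of the methyl in the group's name.

The compounds shown leave open whether the step follows the added ring nitrogen or the move from 6-methyl to 5-methyl, since a 6-methylpyrazin-2-yl or a 5-methylpyridin-2-yl group would be needed to separate the two. They also leave open how other groups on this nitrogen, such as a 5-methylpyrimidin-2-yl or a plain phenyl ring, would read in this assay, and whether the ethyl on the same nitrogen could give way to a longer chain such as propyl.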